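Chloro Gives Way to Cyano on a Shared Core

A few compounds are considered here, and "the series" means these few. Any claim that something is new, unique, unknown or untested is made for them only; others in the source may bear on it.

Of the compounds shown here, three with one shared core have been tested in a functional assay on MDA-MB-468 cells (Homo sapiens) for inhibition; a lower number here means a stronger inhibitor, a higher number a weaker inhibitor. Compound 1 `Cc1cc(N)ccc1-c1nc2ccccc2s1` carries a methyl group; in this assay compound 1 gives < 0.1 nM; < 0.1 nM (2 entries). Compound 2 `Nc1ccc(-c2nc3ccccc3s2)c(Br)c1` carries bromo in its place, and in this assay compound 2 gives < 0.1 nM, which is a limit of the assay and not a number. Compound 3 `Nc1ccc(-c2nc3ccccc3s2)c(Cl)c1` carries chloro, and in this assay compound 3 gives < 0.1 nM, also a limit. Since the values sit at the limit of < 0.1 nM in this assay, at which 2 of the 3 values shown sit, the step that the two limits leave unreadable from compound 2 to compound 3 has no readable size, and compound 3 stands at the limit with no number of its own.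

Compound 4 `N#Cc1cc(N)ccc1-c1nc2ccccc2s1` has not yet been measured; it differs from compound 3 by cyano in place of chloro on an aromatic carbon. Among the compounds with values here, the only measured step, a step that the two limits leave unreadable from compound 2 to compound 3, exchanges one halogen for another and gives no readable size, so there is no gauge for how far a change of the group at this place can move the value. The expected step of an at least 10-fold higher number from compound 3 to compound 4 (1.00 log units; beyond the scatter) is therefore set close to no change, with wide uncertainty. Compound 4 is estimated at 1 nM, within a range from 0.05 nM to 30 nM.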

Compound 4, half-maximal inhibitory concentration: < 0.1 nM
Compound 4 ended at the assay's limit; the forecaster's own chance of this, stated with the estimate: 35%; middle value at least 10-fold (1.00 log units) away from the limit.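

The steps from compound 2 and from compound 3 to compound 4 cannot be read, so cyano in place of bromo or chloro has no measurable size here, because the values all stop at one limit: the limit of < 0.1 nM in this assay, at which 3 of the 4 values shown sit.

The compounds shown leave open whether compound 1, compound 2, compound 3 and compound 4 differ at all in this assay, and by how much.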